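Swapping the Side Chain for Hydrogen on a Shared Core

The source may hold more compounds than are shown below. What is called first, only, known or untested is meant among the compounds shown, and "the series" means these compounds.

Measured so far:
compound 1 `COCC(C)OC(=O)c1c(-c2ccc(OC)c(OC)c2)csc1N`: 49%
compound 2 `COc1ccc(-c2csc(N)c2C(=O)OCc2ccccc2)cc1OC`: 100%

Among the compounds with values here, in an assay on isolated protein for inhibition of protein kinase C zeta type (Homo sapiens), with stated times of 1 h and 2.5 min, tested at 30 uM (a lower number here means less inhibition, a higher number more inhibition at the concentration tested (going by the name of the read-out)), compound 1 gives 49%, the lowest of the two numbers known so far, while compound 2 gives 100%. Within the data shown here, the single measured step, a number 51 percentage points higher from compound 1 to compound 2 (beyond the scatter), shows that exchanging the group sitting on an oxygen next to a carbonyl group can move inhibition a great deal. Compound 3 `COc1ccc(-c2csc(N)c2C(=O)O)cc1OC` has not yet been measured. It differs from compound 1 by hydrogen in place of 1-(methoxymethyl)ethyl on an oxygen next to a carbonyl group. Among the measured compounds shown here, since this change sits at the same place as the one measured step, that step is the only one that bears on it, and it was large. A hydrogen entering is, however, not a benzyl entering, so the direction is uncertain. For compound 3 a step of a number 9 percentage points lower from compound 1 to compound 3 (within the scatter) is expected. Compound 3 is estimated at 40%, within a range from 10% to 80%.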

Compound 3, a percentage reported as inhibition, at one concentration (the size of the read-out at that concentration, not a potency): 65%
For compound 3 the middle estimate is 25 percentage points below the measured one, within the range that was stated.
By their numbers in this assay, from the lowest: compound 1; then compound 3; then compound 2.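

In this assay, hydrogen in place of 1-(methoxymethyl)ethyl on an oxygen next to a carbonyl group gives a number 16 percentage points higher from compound 1 to compound 3 (beyond the scatter) and so shows that removing this side chain does not abolish inhibition. Hydrogen in place of benzyl at the same place gives a number 35 percentage points lower from compound 2 to compound 3 (beyond the scatter) and so goes the other way, which means that the outcome of putting hydrogen here depends on the group it replaces. With hydrogen as the reference point, benzyl raises the number at this place and 1-(methoxymethyl)ethyl lowers it, so these two groups do not merely differ in how much they add.

No measurement shown here explains this order. Still open, as far as these compounds go, is whether a methyl, an ethyl or a longer chain ending in phenyl on this oxygen would read closer to benzyl or to hydrogen.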